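The source may report more compounds than this note shows. Statements on the series, on what has been measured and on what is new or still open speak of the compounds shown alone.

Working notes on the series. Compound 1 `CCOC(=O)c1ccc(-c2nn(Cc3cccc(Cl)c3)c3ccccc23)cc1` and compound 2 `CCOC(=O)c1ccc(-c2nn(Cc3cccc(F)c3)c3ccccc23)cc1` share one core and differ only by fluoro in place of chloro on an aromatic carbon. In a functional assay on cells (Platelet, Homo sapiens) for inhibition (a lower number here means a stronger inhibitor, a higher number a weaker inhibitor), compound 1 gives 80 nM, and in this assay compound 2 gives 270 nM. Among the measured compounds shown here, the step of a 3.4-fold higher number from compound 1 to compound 2 (0.53 log units; beyond the scatter) leaves compound 2 with the higher of the two numbers so far. Compound 3 `CCOC(=O)c1ccc(-c2nn(Cc3ccc(OC)cc3)c3ccccc23)cc1` remains to be measured; the change is 4-methoxyphenyl in place of 3-fluorophenyl on a saturated chain carbon bound to an aromatic nitrogen. For the measured compounds named here, only one measured step exists, a 3.4-fold higher number from compound 1 to compound 2 (0.53 log units; beyond the scatter), and it is a swap of one halogen for another; it offers no reading on a 4-methoxyphenyl group entering in place of the 3-fluorophenyl group. Going by the values given here, with no bearing precedent, no step beyond the scatter is expected in either direction, and the range is kept wide. The estimate for compound 3 is 250 nM (from 70 nM to 900 nM), corresponding to an expected step of a 1.1-fold lower number from compound 2 to compound 3 (0.03 log units; within the scatter).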

Compound 3, half-maximal inhibitory concentration: 620 nM
For compound 3 the middle estimate is 2.5-fold (0.39 log units) below the measured one; the measured number falls inside the stated range.
By their numbers in this assay, from the lowest: compound 1; then compound 2; then compound 3.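

In this assay, the position on a saturated chain carbon bound to an aromatic nitrogen now responds to more than a swap of one halogen for another: 4-methoxyphenyl in place of 3-fluorophenyl gives a 2.3-fold higher number from compound 2 to compound 3 (0.36 log units; beyond the scatter), and in place of 3-chlorophenyl it gives a 7.8-fold higher number from compound 1 to compound 3 (0.89 log units; beyond the scatter). Across the three compounds, the numbers rise from the 3-chlorophenyl group through the 3-fluorophenyl group to the 4-methoxyphenyl group, and each step lies beyond the scatter. No supporting data bear on what lies behind this order.

The change to compound 3 alters both the substituent and its printed ring position, so the two contributions cannot be separated; 3-methoxyphenyl or 4-chlorophenyl groups would divide them. From the compounds shown here alone, how an unsubstituted phenyl group or a carboxylic acid in place of the ethyl ester would read also remains open.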